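A few compounds are considered here, and "the series" means these few. Any claim that something is new, unique, unknown or untested is made for them only; others in the source may bear on it.

Three compounds measured in a functional assay on PC-9 cells (Homo sapiens) for inhibition, read by MTT assay, with a stated time of 72 h (a higher number here means a weaker inhibitor, a lower number a stronger inhibitor), frame this account. Compound 1 `Cc1cc(Nc2cc(-c3ccccc3)[nH]n2)n2nc(SCCCc3ccccc3)nc2n1` gives 5030 nM in this assay, compound 2 `Cc1ccc(CSc2nc3nc(C)cc(Nc4cc(-c5ccccc5)[nH]n4)n3n2)cc1` gives 7310 nM, and compound 3 `Cc1cc(Nc2ccn(Cc3ccc(C(F)(F)F)cc3)n2)n2nc(SCc3ccc(Br)cc3)nc2n1` gives 5580 nM. Compound 2 carries the highest of the three numbers, but its gap to compound 3 and its gap to compound 1 are both within the scatter, so no order among the three can be stated. Among the compounds with values here, the single one-place step among them, a 1.5-fold higher number from compound 1 to compound 2 (0.16 log units; within the scatter), concerns the same position that changes here and did not move the number beyond the scatter.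

Compound 4 `Cc1cc(Nc2cc(-c3ccccc3)[nH]n2)n2nc(SCC3CC3)nc2n1` is not yet measured. It differs from compound 2 in one place: cyclopropyl in place of 4-methylphenyl on a saturated chain carbon bound to a sulfur. Within the data shown here, the only measured step bearing on this position is the one from compound 1 to compound 2, and it was within the scatter; on that basis the step of a 1.2-fold lower number from compound 2 to compound 4 (0.09 log units; within the scatter) is expected to stay within the scatter as well. Compound 4 is therefore estimated at 6000 nM in this assay, with a range from 2500 nM to 15000 nM.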

Compound 4, half-maximal inhibitory concentration: > 50000 nM
Compound 4: a limit, no number (the forecaster's own chance of this, stated with the estimate: 10%); at least 8.3-fold (0.92 log units) between middle value and limit.
By their numbers in this assay, from the lowest: compounds 1, 3 and 2 (each within the scatter of the next). At a limit, above all of these: compound 4.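

Compound 4 stands at a limit of this assay, not at a number: the limit of > 50000 nM in this assay, at which 1 of the 4 values shown sits.

The earlier step at this position, on a saturated chain carbon bound to a sulfur, stayed within the scatter, but cyclopropyl in place of 4-methylphenyl brings an at least 6.8-fold higher number from compound 2 to compound 4 (0.83 log units; beyond the scatter), and cyclopropyl in place of phenethyl brings an at least 9.9-fold higher number from compound 1 to compound 4 (0.99 log units; beyond the scatter). The position therefore does respond to what it carries: the two compounds with a six-membered aromatic ring of carbon only at this place lie within the scatter of each other, while the compound with a three-membered non-aromatic ring does not.

The compounds shown do not separate the loss of the aromatic ring from the lower count of heavy atoms. Going by these compounds, whether a longer saturated chain without a ring, or an amine on the chain, would hold the number near that of compound 1 stays open.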